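The compounds below may be only part of what the source reports. "The series", "measured", "known", "first", "only" and "open" are said of these compounds alone.

In a functional assay on HT-29 cells (Homo sapiens) for antiproliferative activity, with a stated time of 72 h (on this read-out lower numbers stand for stronger inhibition and higher numbers for weaker inhibition), compound 2 `Cn1c(N2N=C(c3ccccc3)CC2c2ccc(Cl)cc2)nc(-c2ccccc2)c(C#N)c1=O` gives 19200 nM, the higher of the two numbers in hand, while compound 1 `Cn1c(N2N=C(c3ccccc3)CC2c2ccccc2)nc(-c2ccccc2)c(C#N)c1=O` gives 2490 nM. Compound 3 `COc1ccc(C2CC(c3ccccc3)=NN2c2nc(-c3ccccc3)c(C#N)c(=O)n2C)cc1` differs from compound 2 by methoxy in place of chloro on an aromatic carbon. Going by the values given here, only one measured step concerns the same aromatic carbon: a 7.7-fold higher number from compound 1 to compound 2 (0.89 log units; beyond the scatter), where chloro replaced hydrogen. Among the compounds with values here, no measured step shows methoxy there, so the direction of the new change is open. Compound 3 is expected to give 7000 nM, within a range from 1500 nM to 30000 nM. That estimate means an expected step of a 2.7-fold lower number from compound 2 to compound 3 (0.44 log units; beyond the scatter), a partial return toward the number of compound 1.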

Compound 3, half-maximal inhibitory concentration: 14700 nM
The estimate for compound 3 lay 2.1-fold (0.32 log units) below the measured number; measured number inside the range.
By their numbers in this assay, from the lowest: compound 1; then compounds 3 and 2 (each within the scatter of the next).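

In this assay, the 4-chlorophenyl and 4-methoxyphenyl groups cannot be told apart, with a 1.3-fold lower number from compound 2 to compound 3 (0.12 log units; within the scatter). Methoxy on this aromatic carbon, like chloro, separates from hydrogen, with a 5.9-fold higher number from compound 1 to compound 3 (0.77 log units; beyond the scatter), so both groups shown here go with a higher number than compound 1 carries. No evidence is available on why the two groups read alike. Still open, on these data alone, is whether an amine or a carboxylic acid on this carbon would match compound 2 and compound 3 or come closer to compound 1. As far as these compounds go, whether methoxy behaves the same way on the other carbons of this ring also remains open.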